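Cyclobutyl sulfonamide extends a small series of piperidine amides

The source may hold more compounds than are shown below. What is called first, only, known or untested is meant among the compounds shown, and "the series" means these compounds.

Measured compounds:
compound 1, `CC(C)c1noc(N2CCN(C(=O)[C@@H]3CCCN(S(=O)(=O)c4ccc(S(=O)(=O)NC5CC5)cc4)C3)CC2)n1`, 6700 nM
compound 2, `CC(C)c1noc(N2CCN(C(=O)[C@@H]3CCCN(S(=O)(=O)c4ccc(S(=O)(=O)NC(C)(C)C)cc4)C3)CC2)n1`, 2600 nM
compound 3, `CC(C)NS(=O)(=O)c1ccc(S(=O)(=O)N2CCC[C@@H](C(=O)N3CCN(c4nc(C(C)C)no4)CC3)C2)cc1`, 2600 nM

In a functional assay on BXPC-3 cells (Homo sapiens) for inhibition, read by MTT assay, with a stated time of 7 days (a lower number here means a stronger inhibitor, a higher number a weaker inhibitor), compound 3 stands level with compound 2, the two together giving the lowest numbers of the three; compound 1 sits apart, as the step of a 2.6-fold lower number from compound 1 to compound 3 (0.41 log units; beyond the scatter) shows. Compound 4, `CC(C)c1noc(N2CCN(C(=O)[C@@H]3CCCN(S(=O)(=O)c4ccc(S(=O)(=O)NC5CCC5)cc4)C3)CC2)n1`, differs from compound 3 by cyclobutyl in place of isopropyl on a sulfonamide nitrogen. Within the data shown here, three measured steps bear on this change, all on the same sulfonamide nitrogen. The steps of a 2.6-fold lower number from compound 1 to compound 2 (0.41 log units; beyond the scatter) and a 2.6-fold lower number from compound 1 to compound 3 (0.41 log units; beyond the scatter) show that replacing cyclopropyl by either acyclic group gave a modest gain, while no change at the digits printed from compound 2 to compound 3 (within the scatter) shows no difference between the two acyclic groups. Among the measured compounds shown here, compound 4 returns to a group with a ring, now four-membered, which the measured set does not cover directly; the only ringed example, compound 1, gave the highest number. A step back toward that number, or none beyond the scatter, is therefore expected, and the estimated step is a 1.5-fold higher number from compound 3 to compound 4 (0.16 log units; within the scatter). For compound 4 the expected value in this assay is 3800 nM, within a range of 1500 nM to 9000 nM.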

Compound 4, half-maximal inhibitory concentration: 3300 nM
Beside the measured number, compound 4's estimate is 1.2-fold (0.06 log units) above it, and the stated range covers the measured number.
By their numbers in this assay, from the lowest: compounds 2, 3 and 4 (each within the scatter of the next); then compound 1.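

In this assay, a ring on the sulfonamide nitrogen no longer goes with the highest number: cyclobutyl shows a 1.3-fold higher number from compound 3 to compound 4 (0.10 log units; within the scatter) and a 1.3-fold higher number from compound 2 to compound 4 (0.10 log units; within the scatter), so it cannot be told apart from the two acyclic groups, while a 2.0-fold lower number from compound 1 to compound 4 (0.31 log units; beyond the scatter) separates it from cyclopropyl. Among these four groups, then, cyclopropyl alone stands apart, and the presence of a ring does not by itself mark out the higher number. Nothing available here gives a cause for the difference between cyclopropyl and the other three groups.

The compounds shown leave open how a cyclopentyl group, a longer chain such as n-butyl, or a group carrying an amine or a carboxylic acid would read on this nitrogen. They also leave open whether compound 2, compound 3 and compound 4 would stay this close on a changed core.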